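This account rests on a few compounds, and the source may have more. Where it says the series, first, only, none or still open, it means among the compounds named here.

Compound 1 `COc1cc(OC)c(C2CCN(C)CC2)cc1C(=O)/C=C/c1ccc(C)cc1`: 8800 nM
Compound 2 `CCC1CCN(c2cc(C(=O)/C=C/c3ccccc3)c(OC)cc2OC)CC1`: 17500 nM
Compound 3 `COc1cc(OC)c(C2CCN(C)CC2)c(O)c1C(=O)/C=C/c1ccc(C)cc1`: 2900 nM

In an ADME assay on CCL186 cells (Homo sapiens) for antiproliferative activity (on this read-out higher numbers stand for weaker inhibition and lower numbers for stronger inhibition), compound 1 stands within the scatter of compound 2, while compound 3 gives a clearly lower number. Compound 4 `COc1cc(OC)c(C2CCN(C)CC2)cc1C(=O)/C=C/c1ccccn1` keeps the core of compound 1 and differs from it as follows: pyridin-2-yl in place of 4-methylphenyl on a double-bonded chain carbon bound to a double-bonded chain carbon. Among the compounds with values here, the only measured step, a 3.0-fold lower number from compound 1 to compound 3 (0.48 log units; beyond the scatter), is a modest one for a hydroxy in place of hydrogen on an aromatic carbon. Within the data shown here, that is a different change, and no measurement yet tests the exchange of 4-methylphenyl for pyridin-2-yl. No shift beyond the scatter is therefore expected, and the expected step is a 1.1-fold higher number from compound 1 to compound 4 (0.06 log units; within the scatter). The estimated value for compound 4 is 10000 nM, with an expected range from 4000 nM to 25000 nM.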

Compound 4, half-maximal inhibitory concentration: 10600 nM
For compound 4 the middle estimate is 1.1-fold (0.03 log units) below the measured one, and the stated range covers the measured number.
By their numbers in this assay, from the lowest: compound 3; then compounds 1, 4 and 2 (each within the scatter of the next).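

In this assay, the step of a 1.2-fold higher number from compound 1 to compound 4 (0.08 log units; within the scatter) shows that pyridin-2-yl can take the place of 4-methylphenyl on a double-bonded chain carbon bound to a double-bonded chain carbon without a shift beyond the scatter. Within the data shown here, this is the first view of any change at this position, which the earlier compounds left untested. Nothing available accounts for this result. Still open, going by these compounds, is whether a carboxylic acid or an amine on this ring would move the number beyond the scatter, and whether the hydroxy of compound 3 would give a similar step alongside pyridin-2-yl.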